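Pivaloyl on the piperazine nitrogen of compound 1

This account rests on a few compounds, and the source may have more. Where it says the series, first, only, none or still open, it means among the compounds named here.

Compound 1 `CNc1ncc2c(-c3ccc(N4CCNCC4)nc3)nn(CC3CCCC3)c2n1` is the starting point of this comparison. In an assay for inhibition of tyrosine-protein kinase receptor TYRO3 (Homo sapiens), read by 33P incorporation, in the presence of a further agent that is not named here (a lower number here means a stronger inhibitor, a higher number a weaker inhibitor), compound 1 gives > 10000 nM, which is a limit of the assay and not a number; where compound 1 stands on the numbers shown is therefore only that limit, and the one further value shown is also a limit. Compound 2 `CNc1ncc2c(-c3ccc(N4CCNCC4)nc3)nn(CC3OCCO3)c2n1` carries a 1,3-dioxolan-2-yl in place of cyclopentyl on a saturated chain carbon bound to an aromatic nitrogen. In this assay compound 2 gives > 10000 nM, again a limit. The step that the two limits leave unreadable from compound 1 to compound 2 is unreadable owing to the limit of > 10000 nM in this assay, at which 2 of the 2 values shown sit.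

Compound 3 `CNc1ncc2c(-c3ccc(N4CCN(C(=O)C(C)(C)C)CC4)nc3)nn(CC3CCCC3)c2n1` differs from compound 1 by (tert-butyl)carbonyl in place of hydrogen on an amine nitrogen in a ring. Going by the values given here, no measured step touches the amine nitrogen in the ring; the single measured step changes a different place and is itself unreadable, so no size or direction beyond the scatter can be drawn from it for this assay. Compound 3 is expected at about 10000 nM, within 2000 nM to 50000 nM. The step of a number no higher from compound 1 to compound 3 (the limit leaves the size open) is thus estimated as none that the limit on compound 1 allows one to read.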

Compound 3, half-maximal inhibitory concentration: > 10000 nM
Compound 3 gave a limit, no number; the forecaster's own chance of this, stated with the estimate: 65%; the middle value sits exactly at the limit.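

In this assay compound 3 gives > 10000 nM, a limit of the assay and not a number. No step can be read from compound 1 to compound 3: the limit of > 10000 nM in this assay, at which 3 of the 3 values shown sit.

The compounds shown leave open whether (tert-butyl)carbonyl on the amine nitrogen in the ring changes inhibition at all, and what on the shared core would give a readable value in this assay.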